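From Compound 2 to Compound 3: a Second Chloro

A few compounds are considered here, and "the series" means these few. Any claim that something is new, unique, unknown or untested is made for them only; others in the source may bear on it.

Compound 1 `CCCc1cc(N)c2cc(NC(=O)/C=C/c3ccc(Br)cc3)ccc2n1` and compound 2 `CCCc1cc(N)c2cc(NC(=O)/C=C/c3ccc(Cl)cc3)ccc2n1` share one core and differ only in the halogen on the phenyl ring. In a functional assay on HEK293 cells for activation of melanin-concentrating hormone receptor 1 (Homo sapiens), read by inositol phosphate accumulation (a lower number here means that less compound is needed, a higher number that more compound is needed for the effect), compound 1 gives 93 nM, while compound 2 gives 96 nM; the step of a 1.0-fold higher number from compound 1 to compound 2 (0.01 log units; within the scatter) stays within the scatter. Compound 2 thus holds the highest of the two numbers, but only by a margin the scatter covers, so no order between the two can be claimed.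

Compound 3 `CCCc1cc(N)c2cc(NC(=O)/C=C/c3ccc(Cl)cc3Cl)ccc2n1` arises from compound 2 by chloro in place of hydrogen on an aromatic carbon; one bond further out, the change reads 4-chlorophenyl to 2,4-dichlorophenyl. Within the data shown here, the single measured step exchanges one halogen for another on the same carbon and does not show what a second chloro adds, so the expectation rests on that step being small. Compound 3 is therefore expected to show no step beyond the scatter, a 1.1-fold lower number from compound 2 to compound 3 (0.03 log units; within the scatter). The estimated value of compound 3 is 90 nM, with a range from 35 nM to 250 nM.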

Compound 3, half-maximal effective concentration: 904 nM
Compound 3: the middle estimate sits 10-fold (1.00 log units) below what was measured, outside the stated range (above it).
By their numbers in this assay, from the lowest: compounds 1 and 2 (each within the scatter of the next); then compound 3.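

In this assay the chloro entering on the aromatic carbon ortho to a large group and meta to a chloro group gives a 9.4-fold higher number from compound 2 to compound 3 (0.97 log units; beyond the scatter) as its step. The earlier exchange of bromo for chloro had stayed within the scatter, so it said nothing about this ring carbon, which carries hydrogen in compound 1 and compound 2 and now proves sensitive to this replacement. The comparison with the 4-bromophenyl group points the same way, with a 9.7-fold higher number from compound 1 to compound 3 (0.99 log units; beyond the scatter) as its step. No measurement shown here explains the size of these steps.

From the compounds shown here alone, whether the step belongs to chloro in particular stays open, as a fluoro or methoxy group on the same carbon could answer that. Going by these compounds, it also remains open whether a 2-chlorophenyl group, without the 4-chloro, would give a similar number.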